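The compounds below may be only part of what the source reports. "The series", "measured", "known", "first", "only" and "open" are said of these compounds alone.

Measured so far in a physicochemical assay for acid dissociation:
- compound 1 `CC(C)(O)CCSc1ccc(S(N)(=O)=O)cc1`: 10
- compound 2 `NS(=O)(=O)c1ccc(S(=O)(=O)CCCO)c(F)c1`: 9.02
- compound 3 `NS(=O)(=O)c1ccc(S(=O)(=O)CCCO)c(C(=O)O)c1`: 9.28

Compound 3, at 9.28, lies within the scatter of compound 2, at 9.02. Compound 1, at 10, stands higher than both, and its gap to compound 3 is beyond the scatter.

The next compound is compound 4 `Nc1cc(S(N)(=O)=O)ccc1S(=O)(=O)CCCO`, which is still to be measured in this assay. It differs from compound 3 at one place: amino in place of carboxy on an aromatic carbon. In words, this is amino in place of carboxy on an aromatic carbon, ortho to a group of 7 heavy atoms and meta to a sulfamoyl group.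

Within the data shown here, one measured step bears on this change, at the same aromatic carbon: a number 0.26 log units higher from compound 2 to compound 3 (within the scatter), with carboxy in place of fluoro. Among the measured compounds shown here, it is small, but it is the only guide, and no compound with the amino group has yet been measured. The data therefore give no firm direction, and no shift beyond the scatter is expected. The expected step is a number 0.12 log units higher from compound 3 to compound 4 (within the scatter).

For compound 4 the estimated value is 9.4, with an expected range from 9 to 9.8.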

Compound 4, acid dissociation constant: 9.15
Beside the measured number, compound 4's estimate is 0.25 log units above it; the range from low to high includes it.
By their numbers in this assay, from the lowest: compounds 2, 4 and 3 (each within the scatter of the next); then compound 1.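

With the amino group, this aromatic carbon has now carried a third substituent, and in this assay the change from carboxy to amino gives a number 0.13 log units lower from compound 3 to compound 4 (within the scatter) and the change from fluoro to amino gives a number 0.13 log units higher from compound 2 to compound 4 (within the scatter) alongside the earlier a number 0.26 log units higher from compound 2 to compound 3 (within the scatter), so all three exchanges among these groups are now in hand. Fluoro, carboxy and amino, ortho to a group of 7 heavy atoms and meta to a sulfamoyl group, are not told apart by this read-out, and even the exchange of carboxy, with 3 heavy atoms, for amino, with 1 heavy atom, stays within the scatter. Nothing in the data at hand accounts for this closeness.

From the compounds shown here alone, whether a methyl group, a nitrile or a trifluoromethyl group on this carbon would also stay this close remains open. Going by these compounds, compound 1, at 10, differs from these compounds in more than one place, so its number cannot be tied to any single change, and what a longer chain in place of the group of 7 heavy atoms would do also stays open.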